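The source may report more compounds than this note shows. Statements on the series, on what has been measured and on what is new or still open speak of the compounds shown alone.

Compound 1 `CC1=CC[C@H]2[C@@H]1CC=C(C)[C@@H](CC[C@H]1[C@]3(C)CC[C@H](O)C(C)(C)O[C@H]3CC[C@@]1(C)O)C2(C)C` is the parent of this small set. In a functional assay on MDA-MB-231 cells (Homo sapiens) for antiproliferative activity, read by MTT assay, with a stated time of 72 h (on this read-out lower numbers stand for stronger inhibition and higher numbers for weaker inhibition), compound 1 gives only a limit, > 50000 nM. For the measured compounds named here, compound 3 `CC1=CC[C@H]2[C@@H]1CC=C(C)[C@@H](CC[C@H]1[C@]3(C)CC[C@H](OCc4ccccc4)C(C)(C)O[C@H]3CC[C@@]1(C)O)C2(C)C` gives 35700 nM in this assay, and the step of an at least 1.4-fold lower number from compound 1 to compound 3 (0.14 log units; that floor lies within the scatter) is the only measured step between structures that differ in one place. Compound 2 `CC1=CC[C@H]2[C@H](CC[C@]2(C)O)C(C)(C)[C@@H]1CC[C@H]1[C@]2(C)CC[C@H](OC(=O)CCC(=O)O)C(C)(C)O[C@H]2CC[C@@]1(C)O` gives 27900 nM in this assay, the lowest of the two numbers, with compound 3 nearest to it and within the scatter. Compound 4 `CC1=CC[C@H]2[C@H](CC[C@]2(C)O)C(C)(C)[C@@H]1CC[C@H]1[C@]2(C)CC[C@H](OC(=O)c3cccc(C(F)(F)F)c3)C(C)(C)O[C@H]2CC[C@@]1(C)O` differs from compound 2 by 3-(trifluoromethyl)phenyl in place of 2-carboxyethyl on a carbonyl carbon. Going by the values given here, no measured step touches this carbonyl carbon, so nothing among the measured steps points to a change beyond the scatter. Compound 4 is therefore expected to give about 25000 nM in this assay, between 7000 nM and 50000 nM, a step of a 1.1-fold lower number from compound 2 to compound 4 (0.05 log units; within the scatter).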

Compound 4, half-maximal inhibitory concentration: 36300 nM
Estimate against measurement, compound 4: 1.5-fold (0.16 log units) below, within the range that was stated.
By their numbers in this assay, from the lowest: compounds 2, 3 and 4 (each within the scatter of the next). At a limit, above all of these: compound 1.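

On this carbonyl carbon, in this assay, 3-(trifluoromethyl)phenyl in place of 2-carboxyethyl gives a 1.3-fold higher number from compound 2 to compound 4 (0.11 log units; within the scatter). For the compounds shown here, the first measured change at this position thus swaps an open chain for an aromatic ring and removes the chain's hydrogen-bond donor, without a shift beyond the scatter. The set also still holds a limit: the limit of > 50000 nM in this assay, at which 1 of the 4 values shown sits.

As far as these compounds go, whether an amine or a longer chain on this carbonyl carbon would move the number beyond the scatter stays open. So does the effect of a carboxylic acid on the aromatic ring.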